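Hydroxymethyl in place of methyl on the benzyl ring

A few compounds are considered here, and "the series" means these few. Any claim that something is new, unique, unknown or untested is made for them only; others in the source may bear on it.

Compound 3 `Cc1ccccc1CC1(C)CC(S(=O)(=O)c2ccc(F)cc2)=C(c2ccc(/C(N)=N/O)cc2)O1` gives 77600 nM in an ADME assay on cells (Peritoneal macrophage, Mus musculus, strain Balb/c) for cytotoxicity, read by resazurin assay, with a stated time of 72 h (on this read-out higher numbers stand for lower toxicity in this test and lower numbers for higher toxicity in this test), which puts it at the top of the two numbers reported there. Compound 2 `Cc1ccc(CC2(C)CC(S(=O)(=O)c3ccc(F)cc3)=C(c3ccc(/C(N)=N/O)cc3)O2)cc1` gives 54400 nM in this assay, and the step of a 1.4-fold higher number from compound 2 to compound 3 (0.15 log units; within the scatter) stays inside the scatter. Compound 1 `COc1ccc(CC2(C)CC(S(=O)(=O)c3ccc(F)cc3)=C(c3ccc(/C(N)=N/O)cc3)O2)cc1` gives only a limit in this assay, > 100000 nM, as noted in the limit of > 100000 nM in this assay, at which 1 of the 3 values shown sits. The remaining steps, an at least 1.8-fold lower number from compound 1 to compound 2 (0.26 log units; that floor lies within the scatter) and an at least 1.2-fold lower number from compound 1 to compound 3 (0.11 log units; that floor lies within the scatter), are likewise modest. Compound 4 `CC1(Cc2ccc(CO)cc2)CC(S(=O)(=O)c2ccc(F)cc2)=C(c2ccc(/C(N)=N/O)cc2)O1` differs from compound 3 by 4-(hydroxymethyl)phenyl in place of 2-methylphenyl on a saturated chain carbon bound to a saturated ring carbon. Every measured step changes the group at this same chain carbon and none moved the number beyond the scatter, so the step of a 1.2-fold higher number from compound 3 to compound 4 (0.06 log units; within the scatter) is expected to be small. Compound 4 is therefore estimated at 90000 nM, with a range from 45000 nM to 200000 nM.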

Compound 4, half-maximal cytotoxic concentration: > 100000 nM
Compound 4 gave a limit, no number (the forecaster's own chance of this, stated with the estimate: 45%); middle value at least 1.1-fold (0.04 log units) from the limit.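

In this assay, hydroxy in place of hydrogen on a saturated chain carbon bound to an aromatic carbon gives an at least 1.8-fold higher number from compound 2 to compound 4 (0.26 log units; that floor lies within the scatter), and 4-(hydroxymethyl)phenyl in place of 2-methylphenyl gives an at least 1.2-fold higher number from compound 3 to compound 4 (0.11 log units; that floor lies within the scatter). The position thus accepts a hydroxymethyl group with no sign of a lower number, and compound 4 shares a limit with compound 1: the limit of > 100000 nM in this assay, at which 2 of the 4 values shown sit. The step between these two compounds cannot be read.

On these data alone, the true values of compound 1 and compound 4 remain open. So does whether an amine or a carboxylic acid on the benzyl ring would bring the number down.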